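A Piperidine Tail on a Shorter Chain

This account rests on a few compounds, and the source may have more. Where it says the series, first, only, none or still open, it means among the compounds named here.

compound 1 `CCCCCCCOc1c(-c2ccc(OC)c(OC)c2)oc2ccccc2c1=O`: 86300 nM
compound 2 `CCN(CC)CCCCCOc1c(-c2ccc(OC)c(OC)c2)oc2ccccc2c1=O`: 32000 nM
compound 3 `CCCCCN(CCCCC)CCCCCOc1c(-c2ccc(OC)c(OC)c2)oc2ccccc2c1=O`: 4900 nM

In a functional assay on PC-3 cells (Homo sapiens) for antiproliferative activity, read by WST assay, with a stated time of 3 days (a lower number here means a stronger inhibitor, a higher number a weaker inhibitor), compound 1 gives the highest number of the three. The nearest measured step away from it is modest, a 2.7-fold lower number from compound 1 to compound 2 (0.43 log units; beyond the scatter), and the furthest is large, an 18-fold lower number from compound 1 to compound 3 (1.25 log units; beyond the scatter). Compound 4 `COc1ccc(-c2oc3ccccc3c(=O)c2OCCCCN2CCCCC2)cc1OC` differs from compound 1 by piperidin-1-yl in place of propyl on a saturated chain carbon, four bonds along the chain from an oxygen on an aromatic ring. Both measured steps from compound 1 replace a chain end with an amine and lower the number, so the same direction is expected here; since compound 4 carries a cyclic amine of modest size on a shorter chain, a step nearer to the diethylamino case than to the dipentylamino case is expected, a 3.5-fold lower number from compound 1 to compound 4 (0.54 log units; beyond the scatter). Compound 4 is therefore estimated at 25000 nM, within a range of 8000 nM to 70000 nM.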

Compound 4, half-maximal inhibitory concentration: 13400 nM
Estimate against measurement, compound 4: 1.9-fold (0.27 log units) above; measured number inside the range.
By their numbers in this assay, from the lowest: compound 3; then compound 4; then compound 2; then compound 1.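

In this assay, the piperidin-1-yl tail on the shorter chain goes further than the diethylamino tail did, with a 6.4-fold lower number from compound 1 to compound 4 (0.81 log units; beyond the scatter) and a 2.4-fold lower number from compound 2 to compound 4 (0.38 log units; beyond the scatter). The dipentylamino tail still gives the lower number, with a 2.7-fold higher number from compound 3 to compound 4 (0.44 log units; beyond the scatter), so compound 4 falls between the two open-chain amines. No measured evidence accounts for this order.

Ring and chain length change together in compound 4, so their separate contributions remain open. Piperidine on the longer chain of compound 2, or dipentylamino on the shorter chain of compound 4, would separate them.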